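Second chloro on the core of compound 1: cytotoxicity expectation

The source may report more compounds than this note shows. Statements on the series, on what has been measured and on what is new or still open speak of the compounds shown alone.

Measured so far:
compound 1 `ClCc1ccc(Cn2cnc3c(Cl)ncnc32)cc1` — 9330 nM
compound 2 `ClCc1cccc(Cn2cnc3ncnc(Cl)c32)c1` — 47900 nM

For the measured compounds named here, in a functional assay on SF-268 cells (Homo sapiens) for cytotoxicity, read by sulforhodamine B assay, with a stated time of 48 h (a lower number here means that less compound is tolerated, a higher number that more compound is tolerated), compound 1 gives 9330 nM, the lowest of the two numbers; compound 2 gives 47900 nM, a difference beyond the scatter, though the two structures differ in more than one place and no single step is defined between them.

Compound 3 `ClCc1ccc(Cn2cnc3c(Cl)nc(Cl)nc32)cc1` is not yet measured. Relative to compound 1 the change is chloro in place of hydrogen on an aromatic carbon, a chloro in place of hydrogen on an aromatic carbon. Going by the values given here, no measured pair isolates this change, so the size of the step in this assay cannot be read from the data. The expectation is a small shift in the direction of a lower number, but one that may well stay within the scatter.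

For compound 3 the estimate in this assay is 7000 nM, range 2500 nM to 20000 nM. The expected step from compound 1 to compound 3 is a 1.3-fold lower number from compound 1 to compound 3 (0.12 log units; within the scatter).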

Compound 3, concentration lethal to 50% of the cells: 42700 nM
The estimate for compound 3 lay 6.1-fold (0.79 log units) below the measured number; measured number above the stated range.
By their numbers in this assay, from the lowest: compound 1; then compounds 3 and 2 (each within the scatter of the next).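

In this assay, the series now has its first step confined to one place, a 4.6-fold higher number from compound 1 to compound 3 (0.66 log units; beyond the scatter), so chloro in place of hydrogen on this aromatic carbon, between two ring nitrogen atoms, raises the number rather than leaving it unchanged. The earlier pair differs in more than one place and could not isolate any single change, whereas this step gives a direction and a size for this change at this position on the core of compound 1. No measurement among those shown gives a reason for the direction of this step.

From the compounds shown here alone, it remains open whether an amine or a methoxy group on the same carbon would give a step of similar direction and size. Also open, going by these compounds, is whether the same chloro change would give a comparable step on compound 2.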